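The compounds below may be only part of what the source reports. "The series", "measured", "known", "first", "only" and "open" are said of these compounds alone.

Measured so far in a functional assay on CHO-K1 cells for antagonist activity at adenosine receptor A1 (Homo sapiens), read by a beta-galactosidase reporter and cAMP accumulation, with stated times of 15 min and 6 h; on this read-out higher numbers stand for weaker inhibition and lower numbers for stronger inhibition:

- compound 1 `Cc1ccc(-c2nc(N)c3ccsc3n2)o1`: 493 nM
- compound 2 `Cc1ccc(-c2nc(N)c3cc(Cc4ccccc4Cl)sc3n2)o1`: 26.1 nM
- compound 3 `Cc1csc(-c2nc(N)c3cc(Cc4ccccc4Cl)sc3n2)n1`: 49.6 nM

Compound 3 stands second highest of the three numbers in this assay; its value sits within the scatter of compound 2, as a 1.9-fold higher number from compound 2 to compound 3 (0.28 log units; within the scatter) shows, while the number of compound 1, 493 nM, lies well above that of compound 3, 49.6 nM.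

Compound 4 `C=C(c1ccccc1)c1cc2c(N)nc(-c3nc(C)cs3)nc2s1` differs from compound 3 in one place: 1-phenylethenyl in place of 2-chlorobenzyl on an aromatic carbon. Going by the values given here, the only step that bears on this position is a 19-fold lower number from compound 1 to compound 2 (1.28 log units; beyond the scatter), which shows that the group at this aromatic carbon carries a large share of the potency in this assay. Compound 4 keeps a six-membered aromatic ring of carbon at the same place but loses the chlorine and exchanges the benzyl linkage for a 1-phenylethenyl. Among the compounds with values here, no measured pair shows the effect of that exchange on its own, so the size of the step is uncertain; the expectation is a modest loss rather than a return to the level of compound 1.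

For compound 4 the estimated step is a 2.2-fold higher number from compound 3 to compound 4 (0.35 log units; beyond the scatter), and the expected value in this assay is 110 nM, with a range from 35 nM to 350 nM.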

Compound 4, inhibition constant: > 594 nM
Compound 4 was reported as a limit (the forecaster's own chance of this, stated with the estimate: 5%); middle value at least 5.4-fold (0.73 log units) away from the limit.
By their numbers in this assay, from the lowest: compounds 2 and 3 (each within the scatter of the next); then compound 1. At a limit, above all of these: compound 4.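

In this assay, placing 1-phenylethenyl in place of 2-chlorobenzyl on the aromatic carbon next to the ring sulfur gives an at least 11-fold higher number from compound 3 to compound 4 (1.07 log units; beyond the scatter), although both groups count 8 heavy atoms and one six-membered aromatic ring of carbon only. The result at this position therefore does not follow from that count and ring alone: the low numbers of compound 2 and compound 3 with 2-chlorobenzyl do not carry over to 1-phenylethenyl. Compound 4 is reported as a limit, not a number: the limit of > 594 nM in this assay, at which 1 of the 4 values shown sits.

The change removes the chlorine and alters the linkage to the ring together, so the compounds shown cannot separate the two; a plain benzyl or a 1-phenylethyl group at this carbon would. Going by these compounds, whether the step holds with 5-methylfuran-2-yl in place of 4-methyl-1,3-thiazol-2-yl also stays open.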